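Extending the methylamino group of compound 3 to a hydroxybutyl chain

The source may hold more compounds than are shown below. What is called first, only, known or untested is meant among the compounds shown, and "the series" means these compounds.

Compound 3 `CNc1ncc(-c2cccc(Cl)c2)c(-c2ccccc2)n1` stands highest of the three compounds measured in an assay on CHO cells for displacement of a labelled ligand from adenosine receptor A1 (Homo sapiens), read by scintillation counting, with a stated time of 1 h, tested at 1 uM (on this read-out higher numbers stand for more inhibition at the one concentration tested (going by the name of the read-out) and lower numbers for less inhibition), where compound 3 gives 75%. Compound 2 `CC(C)CC(=O)Nc1ncc(-c2cccc(Cl)c2)c(-c2ccccc2)n1` gives 56% and compound 1 `Nc1ncc(-c2ccc(Cl)cc2)c(-c2ccccc2)n1` gives 41%. For the measured compounds named here, the one single-point step in the set, a number 19 percentage points higher from compound 2 to compound 3 (beyond the scatter), runs in favour of the smaller substituent on the ring nitrogen. Compound 4 `OCCCCNc1ncc(-c2cccc(Cl)c2)c(-c2ccccc2)n1` differs from compound 3 by 3-hydroxypropyl in place of hydrogen on a saturated chain carbon bound to a nitrogen on an aromatic ring. Going by the values given here, no measured step adds a chain at this position, so the only bearing is indirect: the methyl-for-isobutylcarbonyl step shows that this nitrogen is sensitive to substitution. A modest downward step is expected, a number 15 percentage points lower from compound 3 to compound 4 (beyond the scatter), with wide uncertainty. Compound 4 is estimated at 60%, within 30% to 85%.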

Compound 4, a percentage reported as inhibition, at one concentration (the size of the read-out at that concentration, not a potency): > 80%
Compound 4: a limit, no number (the forecaster's own chance of this, stated with the estimate: 0%); at least 20 percentage points between middle value and limit.
By their numbers in this assay, from the lowest: compound 1; then compound 2; then compound 3. At a limit, above all of these: compound 4.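

In this assay compound 4 gives > 80%, a limit and not a number: the limit of > 80% in this assay, at which 1 of the 4 values shown sits.

For the compounds shown here, the nitrogen on the aromatic ring, so far seen only with methyl and isobutylcarbonyl, also carries a 4-hydroxybutyl chain without loss, and the chain stands clearly ahead of the acylated form: a number at least 24 percentage points higher from compound 2 to compound 4 (beyond the scatter). Against methyl no gain can be claimed: a number at least 5 percentage points higher from compound 3 to compound 4 (that floor lies within the scatter).

As far as these compounds go, whether the hydroxyl itself contributes remains open, as does how much chain length this position accepts. A plain butyl chain, a longer chain, or an amine in place of the hydroxyl would address both.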